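From Methylsulfonyl to Cyano: Metabolic Stability of Compound 4

The source may report more compounds than this note shows. Statements on the series, on what has been measured and on what is new or still open speak of the compounds shown alone.

Compound 3 `CC(=O)N1CCN(c2cc(-c3cc(Cl)c4c(N)ncnn34)ccc2S(C)(=O)=O)C(=O)C1(C)C` stands second highest of the three numbers measured in an ADME assay on microsomes from liver (Mus musculus) for metabolic stability, read by LC-MS, using NADPH, with stated times of 6 min and 10 min, tested at 0.5 uM (a lower number here means that less of the compound is left, a higher number that more of the compound is left), where compound 3 gives 84%. Its nearest neighbour is compound 2 `COc1ccc(-c2cc(Cl)c3c(N)ncnn23)cc1N1CCN(C(C)=O)C(C)(C)C1=O`, which in this assay gives 94%; the furthest is compound 1 `CC(=O)N1CCN(c2cc(C)cc(-c3cc(Cl)c4c(N)ncnn34)c2)C(=O)C1(C)C`, which in this assay gives 45%. Among the compounds with values here, the single recorded step between measured compounds that differ in one place, methylsulfonyl in place of methoxy on an aromatic carbon, is a number 10 percentage points lower from compound 2 to compound 3 (within the scatter). Compound 4 `CC(=O)N1CCN(c2cc(-c3cc(Cl)c4c(N)ncnn34)ccc2C#N)C(=O)C1(C)C` follows from compound 3 by cyano in place of methylsulfonyl on an aromatic carbon. Within the data shown here, no measured step swaps methylsulfonyl for cyano, so that one within-scatter step is the only guide, and in this assay a step of similar size is expected, none beyond the scatter. Compound 4 is therefore expected to give 78%, ranging from 55% to 95%, a shift of a number 6 percentage points lower from compound 3 to compound 4 (within the scatter).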

Compound 4, percent of the compound remaining: 89%
For compound 4 the middle estimate is 11 percentage points below the measured one, within the range that was stated.
By their numbers in this assay, from the lowest: compound 1; then compounds 3, 4 and 2 (each within the scatter of the next).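

In this assay, cyano in place of methylsulfonyl on this aromatic carbon is a number 5 percentage points higher from compound 3 to compound 4 (within the scatter), and cyano in place of methoxy is a number 5 percentage points lower from compound 2 to compound 4 (within the scatter). With the earlier step, methoxy, methylsulfonyl and cyano are now linked by steps that all stay within the scatter, so replacing four heavy atoms with two changes little here. No measurement shown bears on the reason for this. As far as these compounds go, whether the same holds at this position for an amine, a carboxylic acid or a longer chain stays open.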